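A few compounds are considered here, and "the series" means these few. Any claim that something is new, unique, unknown or untested is made for them only; others in the source may bear on it.

Measured so far:
compound 1, `CC1=C(C(=O)Nc2ccc([N+](=O)[O-])cc2)C(c2ccc(Br)cc2)N=C(SCc2cccc(Cl)c2)N1`, 6.7%
compound 2, `CC1=C(C(=O)Nc2ccc([N+](=O)[O-])cc2)C(c2cccc([N+](=O)[O-])c2)N=C(SCc2ccccc2Cl)N1`, 7.7%

Both numbers come from a functional assay on the whole organism (artery, strain albino) with Rattus norvegicus as the target, with a stated time of 120 min, at a dose of 10 mg/kg by the oral route; a higher number here means more inhibition at the dose given (going by the name of the read-out), a lower number less inhibition. Compound 1 gives 6.7% in this assay, and compound 2 gives 7.7%. Compound 2 holds the higher of the two numbers, but the gap to compound 1 lies within the scatter, so the two read as the same.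

The next compound is compound 3, `CC1=C(C(=O)Nc2ccc([N+](=O)[O-])cc2)C(c2cccc([N+](=O)[O-])c2)N=C(SCc2cccc(Cl)c2)N1`, which has not yet been measured in this assay. It is built from compound 2 by one rearrangement: 3-chlorophenyl in place of 2-chlorophenyl on a saturated chain carbon bound to a sulfur. For the measured compounds named here, no comparable pair among the measured compounds is available, so the size of this step cannot be read off directly. What the data do show is that compound 1, which carries the 3-chlorobenzyl group found in compound 3, and compound 2, which carries the 2-chlorobenzyl group, give values within the scatter of each other. No step beyond the scatter is therefore expected from this change, in either direction. The expected step from compound 2 to compound 3 is a number 0.7 percentage points lower from compound 2 to compound 3 (within the scatter). For compound 3 the estimate in this assay is 7%, expected to lie between 0% and 20%.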

Compound 3, a percentage reported as inhibition, in the whole organism at one dose (the size of the read-out at that dose, not a potency): 12.4%
The estimate for compound 3 lay 5.4 percentage points below the measured number, within the range that was stated.
By their numbers in this assay, from the lowest: compounds 1, 2 and 3 (each within the scatter of the next).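

In this assay, for the compounds shown here, 3-chlorophenyl in place of 2-chlorophenyl on a saturated chain carbon bound to a sulfur gives the first direct reading of this change with the rest of the molecule held fixed (a number 4.7 percentage points higher from compound 2 to compound 3 (within the scatter)), and at this dose the two placements of the chlorine on the benzyl group are not told apart. Compound 3 also provides a direct comparison at a second site, where 3-nitrophenyl in place of 4-bromophenyl on a saturated ring carbon likewise does not separate the pair (a number 5.7 percentage points higher from compound 1 to compound 3 (within the scatter)). No independent measurement bears on this result, so neither step can be tied to anything beyond the numbers themselves.

The compounds shown leave open whether an unsubstituted benzyl group or a longer chain on the sulfur would give a number beyond the scatter. As far as these compounds go, it is equally open whether an amine or a carboxylic acid in place of the nitro group of 3-nitrophenyl would move the number in this whole-animal test.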